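The source may hold more compounds than are shown below. What is called first, only, known or untested is meant among the compounds shown, and "the series" means these compounds.

Measured so far in a functional assay on the whole organism (artery, strain albino) with Rattus norvegicus as the target, with a stated time of 60 min, at a dose of 10 mg/kg by the oral route; a lower number here means less inhibition, a higher number more inhibition at the dose given (going by the name of the read-out): compound 1 `COc1ccc(C2N=C(SCc3ccccc3Cl)NC(C)=C2C(=O)Nc2ccc(Br)cc2)cc1` gives 6.7%; compound 2 `COc1ccc(C2N=C(SCc3cccc(Cl)c3)NC(C)=C2C(=O)Nc2ccc(Br)cc2)cc1` gives 15.4%.

Compound 2 is reached from compound 1 by the step of a number 8.7 percentage points higher from compound 1 to compound 2 (within the scatter), which lies within the scatter, so the two compounds are not separated by these numbers. Compound 3 `COc1ccc(C2N=C(SCc3ccc(F)cc3)NC(C)=C2C(=O)Nc2ccc(Br)cc2)cc1` differs from compound 2 by 4-fluorophenyl in place of 3-chlorophenyl on a saturated chain carbon bound to a sulfur. Going by the values given here, the only measured step at this same place, a number 8.7 percentage points higher from compound 1 to compound 2 (within the scatter), stayed within the scatter, so the change to compound 3 is expected to give no step beyond the scatter, a number 3.4 percentage points lower from compound 2 to compound 3 (within the scatter). The estimate for compound 3 in this assay is 12%, with a range from 0% to 28%.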

Compound 3, a percentage reported as inhibition, in the whole organism at one dose (the size of the read-out at that dose, not a potency): 8.7%
The estimate for compound 3 lay 3.3 percentage points above the measured number; measured number inside the range.
By their numbers in this assay, from the lowest: compounds 1, 3 and 2 (each within the scatter of the next).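

In this assay, the 4-fluorophenyl group on a saturated chain carbon bound to a sulfur gives a number 6.7 percentage points lower from compound 2 to compound 3 (within the scatter) and a number 2 percentage points higher from compound 1 to compound 3 (within the scatter). The three halogen-bearing phenyl groups at this place are therefore not separated by these numbers, and changing chlorine to fluorine together with the ring position gives no step beyond the scatter. No evidence bears on this result. As far as these compounds go, whether a phenyl ring carrying an amine or a carboxylic acid, or a longer chain in place of the benzyl group, gives a step beyond the scatter stays open.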